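Swapping the ring on the sulfur: thiazole to oxadiazole

The source may hold more compounds than are shown below. What is called first, only, known or untested is meant among the compounds shown, and "the series" means these compounds.

Compound 1, `CC(C)[C@H](NC(=O)COc1cccc2ccccc12)C(=O)N[C@@H](CC(=O)O)C(=O)CSc1ncc[nH]1`, in a functional assay on Jurkat cells (Homo sapiens) for inhibition (a lower number here means a stronger inhibitor, a higher number a weaker inhibitor), reaches only the assay limit, > 200000 nM.
Compound 2, `CC(C)[C@H](NC(=O)COc1cccc2ccccc12)C(=O)N[C@@H](CC(=O)O)C(=O)CSc1nccn1C`, in this assay also reaches only the assay limit, > 200000 nM.
Compound 3, `CC(C)[C@H](NC(=O)COc1cccc2ccccc12)C(=O)N[C@@H](CC(=O)O)C(=O)CSc1nc(-c2ccccc2)cs1`, in this assay likewise reaches only the assay limit, > 200000 nM.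

Compound 3 therefore stands at a limit rather than at a number, and the same holds for both other compounds shown. Going by the values given here, none of the measured steps can be read: a step that the two limits leave unreadable from compound 1 to compound 2, a step that the two limits leave unreadable from compound 1 to compound 3, and a step that the two limits leave unreadable from compound 2 to compound 3. This follows from the limit of > 200000 nM in this assay, at which 3 of the 3 values shown sit, so no change to the ring on the sulfur has yet produced a measurable inhibitor in this series.

Compound 4, `CC(C)[C@H](NC(=O)COc1cccc2ccccc12)C(=O)N[C@@H](CC(=O)O)C(=O)CSc1nc(-c2ccccc2)no1`, differs from compound 3 only in that ring: 3-phenyl-1,2,4-oxadiazol-5-yl in place of 4-phenyl-1,3-thiazol-2-yl on a sulfur. Among the compounds with values here, the one earlier exchange of this ring, from compound 1 or compound 2 to compound 3, left the value at the limit, and no step here gives a direction or a size. The expectation for this assay is thus no readable step, a number no higher from compound 3 to compound 4 (the limit leaves the size open), with compound 4 most likely again reported as a limit. The estimate for compound 4 is 200000 nM, with a range from 50000 nM to 1000000 nM.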

Compound 4, half-maximal inhibitory concentration: 102000 nM
The estimate for compound 4 lay 2.0-fold (0.29 log units) above the measured number; the measured number falls inside the stated range.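

In this assay, going by these compounds alone, compound 4 is the first compound here to give a number rather than a limit, which shows that exchanging the ring on the sulfur can bring a value into readable range, even though the thiazole, imidazole and methylimidazole rings did not. Against the three earlier rings, the exchange gives an at least 1.9-fold lower number from compound 3 to compound 4 (0.29 log units; that floor lies within the scatter), an at least 1.9-fold lower number from compound 2 to compound 4 (0.29 log units; that floor lies within the scatter) and an at least 1.9-fold lower number from compound 1 to compound 4 (0.29 log units; that floor lies within the scatter). Each of these steps is only a floor, and the steps among compound 1, compound 2 and compound 3 cannot be read at all, because one or both ends of every step are a limit: the limit of > 200000 nM in this assay, at which 3 of the 4 values shown sit.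

The compounds shown do not tell whether the 3-phenyl-1,2,4-oxadiazol-5-yl group gains anything real over the 4-phenyl-1,3-thiazol-2-yl group, since the true gap could lie within the usual scatter or well beyond it. They also leave open what a 1,3,4-oxadiazol-2-yl ring would do, or a phenyl group carrying an amine or a carboxylic acid, and whether any such change would bring the number far lower.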